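Pendant aryl changes on the shared core

A few compounds are considered here, and "the series" means these few. Any claim that something is new, unique, unknown or untested is made for them only; others in the source may bear on it.

Compound 1 `COc1ccc(-c2nc3cccc(-c4cc(OC)c(OC)c(OC)c4)c3o2)cc1OC` carries a 3,4-dimethoxyphenyl group on the shared core. Among the measured compounds shown here, in a functional assay on U-251 cells (Homo sapiens) for antiproliferative activity, read by MTT assay, with a stated time of 48 h (on this read-out lower numbers stand for stronger inhibition and higher numbers for weaker inhibition), compound 1 gives 1300 nM, the lowest of the three numbers so far; compound 3 sits within the scatter of it and compound 2 beyond it. Compound 2 `COc1cc(-c2cccc3nc(-c4cccc(F)c4)oc23)cc(OC)c1OC` gives 2900 nM in this assay, and compound 3 `COc1cc(-c2cccc3nc(-c4ccc(Cl)cc4)oc23)cc(OC)c1OC` gives 1600 nM. The steps are a 2.2-fold higher number from compound 1 to compound 2 (0.35 log units; beyond the scatter), a 1.2-fold higher number from compound 1 to compound 3 (0.09 log units; within the scatter) and a 1.8-fold lower number from compound 2 to compound 3 (0.26 log units; within the scatter).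

Compound 4 `COc1cc(-c2cccc3nc(-c4cccc(O)c4)oc23)cc(OC)c1OC` is not yet measured in this assay. Against compound 1 the change is 3-hydroxyphenyl in place of 3,4-dimethoxyphenyl on an aromatic carbon.

The two measured steps away from compound 1 both swap the same group for a smaller phenyl carrying a single halogen. One of them, a 2.2-fold higher number from compound 1 to compound 2 (0.35 log units; beyond the scatter), is modest but beyond the scatter; the other, a 1.2-fold higher number from compound 1 to compound 3 (0.09 log units; within the scatter), stays inside it. For the measured compounds named here, no measured step introduces a hydrogen-bond donor, so the effect of the hydroxyl itself is unknown here. The swap to 3-hydroxyphenyl is therefore expected to behave like the halogen swaps: a step of a 1.5-fold higher number from compound 1 to compound 4 (0.19 log units; within the scatter) is expected, at most modest and possibly within the scatter. Compound 4 is estimated to give 2000 nM in this assay, within a range from 800 nM to 5000 nM.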

Compound 4, half-maximal inhibitory concentration: 5500 nM
The estimate for compound 4 lay 2.8-fold (0.44 log units) below the measured number, and the stated range ends below it.
By their numbers in this assay, from the lowest: compounds 1, 3, 2 and 4 (each within the scatter of the next, the first and the last beyond it).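

In this assay, the 3-hydroxyphenyl group brings the only hydrogen-bond donor in the series to this position, and the swap gives a 4.2-fold higher number from compound 1 to compound 4 (0.63 log units; beyond the scatter), with a 3.4-fold higher number from compound 3 to compound 4 (0.54 log units; beyond the scatter) also beyond the scatter. The hydroxyl does not stand clearly apart from the fluoro group on the same ring, though: a 1.9-fold higher number from compound 2 to compound 4 (0.28 log units; within the scatter) stays within the scatter, so the donor cannot be separated from the fluoro group in this assay, and both singly substituted 3-position rings lie beyond the scatter of compound 1, while the 4-chlorophenyl ring of compound 3 does not. No measurement at hand explains these steps or ties them to the donor itself.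

Open, as far as these compounds go, is whether the higher number in compound 4 follows from the hydroxyl itself, from its place on the ring, or simply from the absence of the second methoxy group of the 3,4-dimethoxyphenyl ring. A 3-methoxyphenyl, 4-hydroxyphenyl or 3-aminophenyl group at this position would help separate these readings, and a 3-carboxyphenyl group would show how far the trend extends to a carboxylic acid.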